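Aryl swap on the ring nitrogen of the shared core

The compounds below may be only part of what the source reports. "The series", "measured", "known", "first", "only" and "open" are said of these compounds alone.

Measured so far:
- compound 1, `Cc1cccc(-c2nc(CNc3ccc(C(=O)NO)cc3)n(-c3ccccc3)n2)c1`: 281 nM
- compound 2, `O=C(NO)c1ccc(NCc2nc(-c3ccccc3)nn2-c2cccc(Cl)c2)cc1`: 678 nM

Both values come from an assay on Sf9 cells for inhibition of protein deacetylase HDAC6 (Homo sapiens), read by fluorescence, with a stated time of 40 min; a lower number here means a stronger inhibitor, a higher number a weaker inhibitor. Compound 2 gives the highest of the two numbers; its nearest neighbour, compound 1, sits lower by a margin beyond the usual scatter. Going by the values given here, no single-point step between the two measured compounds can be drawn, since they differ in more than one place.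

Compound 3, `Cc1ccc(-n2nc(-c3ccccc3)nc2CNc2ccc(C(=O)NO)cc2)cc1`, is not yet measured. It is derived from compound 2 by one change: 4-methylphenyl in place of 3-chlorophenyl on an aromatic nitrogen. Among the compounds with values here, with no measured step for this kind of exchange, the size of the effect in this assay is open; a shift within or slightly beyond the scatter, in either direction, is the working expectation, with a mild lean toward a lower number.

Compound 3 is expected to give about 500 nM, within 200 nM to 1500 nM. The expected step is a 1.4-fold lower number from compound 2 to compound 3 (0.13 log units; within the scatter).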

Compound 3, half-maximal inhibitory concentration: 310 nM
Beside the measured number, compound 3's estimate is 1.6-fold (0.21 log units) above it, and the stated range covers the measured number.
By their numbers in this assay, from the lowest: compounds 1 and 3 (each within the scatter of the next); then compound 2.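

In this assay, going by these compounds alone, this is the first single-place reading, and it shows that the aryl group on the aromatic nitrogen of the shared core affects the number: 4-methylphenyl in place of 3-chlorophenyl gives a 2.2-fold lower number from compound 2 to compound 3 (0.34 log units; beyond the scatter). The step is modest but beyond the scatter, and it comes from an exchange that keeps the heavy-atom count and the six-membered aromatic carbon ring unchanged. Nothing at hand offers an explanation for this step.

The exchange alters both the substituent and its location on the aryl ring, and the compounds shown do not separate these two contributions. As far as these compounds go, how this position responds to a methoxy group or an amine on the aryl ring, or to cyclohexyl in place of the aryl ring, remains open.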